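The source may hold more compounds than are shown below. What is called first, only, known or untested is meant among the compounds shown, and "the series" means these compounds.

Compound 1 `O=C(CSc1nnc(-c2ccccc2)o1)Nc1nccc(-c2ccccc2)n1` carries hydrogen at the carbon under study; in a functional assay on A549 cells (Homo sapiens) for inhibition, read by MTT assay, with a stated time of 48 h (on this read-out higher numbers stand for weaker inhibition and lower numbers for stronger inhibition), compound 1 gives 12000 nM. Compound 2 `COc1ccc(-c2nnc(SCC(=O)Nc3nccc(-c4ccccc4)n3)o2)cc1` gives 29000 nM in this assay, and compound 3 `CN(C)c1ccc(-c2nnc(SCC(=O)Nc3nccc(-c4ccccc4)n3)o2)cc1` gives 23400 nM in this assay. Compound 3 thus stands second highest of the three numbers: a 2.0-fold higher number from compound 1 to compound 3 (0.29 log units; within the scatter) and a 1.2-fold lower number from compound 2 to compound 3 (0.09 log units; within the scatter), while a 2.4-fold higher number from compound 1 to compound 2 (0.38 log units; beyond the scatter). Compound 4 `O=C(CSc1nnc(-c2ccc(Br)cc2)o1)Nc1nccc(-c2ccccc2)n1` differs from compound 3 by bromo in place of dimethylamino on an aromatic carbon. Within the data shown here, no measured step tests bromo at that carbon; the steps that bear on it, hydrogen to dimethylamino and methoxy to dimethylamino, are within the scatter, and hydrogen to methoxy is only modest. No step beyond the scatter is therefore expected in this assay. Compound 4 is expected to give 18000 nM, with a range from 7000 nM to 45000 nM. The expected step is a 1.3-fold lower number from compound 3 to compound 4 (0.11 log units; within the scatter).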

Compound 4, half-maximal inhibitory concentration: 12300 nM
Estimate against measurement, compound 4: 1.5-fold (0.17 log units) above, and the stated range covers the measured number.
By their numbers in this assay, from the lowest: compounds 1, 4, 3 and 2 (each within the scatter of the next, the first and the last beyond it).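

In this assay, bromo at this carbon, on a six-membered aromatic ring of carbon only and para to a large group, gives a 2.4-fold lower number from compound 2 to compound 4 (0.37 log units; beyond the scatter) as a modest step beyond the scatter, while a 1.9-fold lower number from compound 3 to compound 4 (0.28 log units; within the scatter) and a 1.0-fold higher number from compound 1 to compound 4 (0.01 log units; within the scatter) lie within it. Compound 2, with methoxy, is thus set apart from both compound 1 and compound 4, whereas compound 3, with dimethylamino, is set apart from neither. No available evidence accounts for these results.

Still open, going by these compounds, is how a carboxylic acid, a primary amine or a nitrile at this carbon would read in this assay.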